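This account rests on a few compounds, and the source may have more. Where it says the series, first, only, none or still open, it means among the compounds named here.

The measured compounds:

Compound 1 `COc1cccc(/C=C2\CCC/C(=C\c3cccc(OC)c3OC)C2=O)c1`: 16400 nM
Compound 2 `COc1ccc(/C=C2\CCC/C(=C\c3cccc(OC)c3OC)C2=O)cc1`: > 20000 nM (a limit)
Compound 3 `COc1cccc(/C=C2\CCC/C(=C\c3ccc(OC)c(OC)c3)C2=O)c1`: 6700 nM

All three were tested in a functional assay on A549 cells (Homo sapiens) for cytotoxicity, read by MTT assay, with a stated time of 72 h; on this read-out higher numbers stand for weaker inhibition and lower numbers for stronger inhibition. Compound 1 gives 16400 nM in this assay. Compound 2 gives > 20000 nM, which is a limit of the assay and not a number. Compound 3 gives 6700 nM, the lowest of the two numbers recorded; against compound 1 it stands a step beyond the scatter.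

Compound 1 and compound 2 differ in one place: 4-methoxyphenyl in place of 3-methoxyphenyl on a double-bonded chain carbon bound to a double-bonded ring carbon. This change made an at least 1.2-fold higher number from compound 1 to compound 2 (0.08 log units; that floor lies within the scatter), a floor that lies within the scatter, because the limit of > 20000 nM in this assay, at which 1 of the 3 values shown sits, is all that is known of compound 2. Compound 3 and compound 1 differ in their cores, and that difference is not broken down here.

Compound 4 `COc1ccc(/C=C2\CCC/C(=C\c3ccc(OC)c(OC)c3)C2=O)cc1` has not yet been measured in this assay. It relates to compound 3 as compound 2 relates to compound 1, the same change at the same place: 4-methoxyphenyl in place of 3-methoxyphenyl on a double-bonded chain carbon bound to a double-bonded ring carbon. The only earlier occurrence of this change is the step from compound 1 to compound 2, whose size is known only as a floor. On that slender basis compound 4 is expected to show a somewhat higher number than compound 3, an estimated 1.8-fold higher number from compound 3 to compound 4 (0.25 log units; within the scatter). The estimate for compound 4 is 12000 nM, with a likely range from 5000 nM to 30000 nM.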

Compound 4, half-maximal inhibitory concentration: > 20000 nM
Compound 4: only a limit was reported (the forecaster's own chance of this, stated with the estimate: 25%); middle value at least 1.6-fold (0.22 log units) from the limit.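

In this assay compound 4 gives > 20000 nM, which is a limit of the assay and not a number. Carried to the second core, 4-methoxyphenyl in place of 3-methoxyphenyl gives an at least 2.9-fold higher number from compound 3 to compound 4 (0.47 log units; beyond the scatter), so here the change clearly goes with a higher number, while the floor on the first core shows no step beyond the scatter and only leaves room for one. The result therefore fits a change that carries over in the same direction, but it does not show that the step is the same size on both cores, nor that it is larger on one of them: the same change on two cores in this assay, an at least 1.2-fold higher number (0.08 log units; that floor lies within the scatter) from compound 1 to compound 2 and an at least 2.9-fold higher number (0.47 log units; beyond the scatter) from compound 3 to compound 4; the limit leaves it open whether they differ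

From the compounds shown here alone, how far compound 2 and compound 4 lie past that limit remains unknown, and with it the true size of both steps: the limit of > 20000 nM in this assay, at which 2 of the 4 values shown sit. Also open is whether a hydroxyl group or an amine in place of the methoxy group at this place on a double-bonded chain carbon bound to a double-bonded ring carbon would give readable numbers in this assay, and so allow the two cores to be compared directly.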